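Lipophilicity notes: bromo to ethoxycarbonyl on the aryl ring

The source may report more compounds than this note shows. Statements on the series, on what has been measured and on what is new or still open speak of the compounds shown alone.

Compound 1 `CC(=O)N[C@@H](C)C(=O)N(C)/N=N/c1ccc(Br)cc1` is the reference point of this pair. Within the data shown here, in a physicochemical assay for lipophilicity, read by HPLC, in phosphate buffer, measured as octanol-water partition, at pH 7.4 (a lower number here means a more polar compound, a higher number a more lipophilic compound), compound 1 gives 2.8, the higher of the two numbers measured so far. Among the measured compounds shown here, compound 2 `CC(=O)N[C@@H](C)C(=O)N(C)/N=N/c1ccc(C(N)=O)cc1` carries carbamoyl where compound 1 carries bromo; in this assay compound 2 gives 0.69, and the step of a number 2.11 log units lower from compound 1 to compound 2 (beyond the scatter) is the only measured change on the shared core.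

Compound 3 `CCOC(=O)c1ccc(/N=N/N(C)C(=O)[C@H](C)NC(C)=O)cc1` differs from compound 1 as follows: ethoxycarbonyl in place of bromo on an aromatic carbon. For the measured compounds named here, the one measured step, bromo to carbamoyl, bears on this change and was large. Ethoxycarbonyl enters in place of bromo with an ethyl chain and no donors, so a decrease is expected, but a smaller one than the step to compound 2 showed. The step from compound 1 to compound 3 is expected to be a number 0.40 log units lower from compound 1 to compound 3 (beyond the scatter), near the edge of the scatter. For compound 3 the estimate in this assay is 2.4, with a range from 1.9 to 2.9.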

Compound 3, partition coefficient: 2.52
The estimate for compound 3 lay 0.12 log units below the measured number; the range from low to high includes it.
By their numbers in this assay, from the lowest: compound 2; then compounds 3 and 1 (each within the scatter of the next).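

In this assay the aromatic carbon takes ethoxycarbonyl in place of bromo with a number 0.28 log units lower from compound 1 to compound 3 (within the scatter), so this replacement, unlike carbamoyl in place of bromo, cannot be told apart from no change. The large change instead appears on the carbonyl carbon: ethoxy in place of amino gives a number 1.83 log units higher from compound 2 to compound 3 (beyond the scatter), which takes back most of a number 2.11 log units lower from compound 1 to compound 2 (beyond the scatter). A carbonyl on this aromatic carbon therefore does not by itself set the number, since compound 2 and compound 3 both carry one and still lie far apart. No supporting measurement accounts for these steps.

Going by these compounds, it remains open how the number responds to the ester chain, which a methyl ester or a longer chain would address. Where a carboxylic acid or an amine at this position would stand also remains open.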